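The source may hold more compounds than are shown below. What is called first, only, known or untested is meant among the compounds shown, and "the series" means these compounds.

Measured in a functional assay on MCF7 cells (Homo sapiens) for antiproliferative activity, read by sulforhodamine B assay, with a stated time of 48 h; on this read-out lower numbers stand for stronger inhibition and higher numbers for weaker inhibition:
- compound 1 `COc1ccccc1OS(=O)(=O)c1ccc(N2CCN(C)C2=O)cc1` gives 26000 nM
- compound 2 `CCCN1CCN(c2ccc(S(=O)(=O)Oc3ccccc3C)cc2)C1=O` gives > 100000 nM (a limit of the assay)
- compound 3 `CCCN1CCN(c2ccc(S(=O)(=O)Oc3ccccc3CC)cc2)C1=O` gives 2300 nM

For the measured compounds named here, compound 3 has the lowest number of the series so far, and its gap to compound 1 lies beyond the scatter. Compound 4 `CCCN1CCN(c2ccc(S(=O)(=O)Oc3ccccc3OC)cc2)C1=O` has methoxy in place of ethyl on an aromatic carbon, ortho to a large group (methoxy in place of ethyl on an aromatic carbon).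

Going by the values given here, the only measured step is an at least 43-fold lower number from compound 2 to compound 3 (1.63 log units; beyond the scatter), a large change at the group now being replaced. It starts from a limit. It shows that this site can matter, but it does not measure methoxy directly. Compound 1 also carries 2-methoxyphenyl and differs from compound 4 elsewhere. In compound 1 the value of 26000 nM points to weaker inhibition than in compound 3.

A higher number in this assay is therefore expected, of moderate size and uncertain: a 3.5-fold higher number from compound 3 to compound 4 (0.54 log units; beyond the scatter) is the estimated step. For compound 4 the estimated value is 8000 nM, with an expected range from 2000 nM to 30000 nM.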

Compound 4, half-maximal inhibitory concentration: 13000 nM
Compound 4: the middle estimate sits 1.6-fold (0.21 log units) below what was measured, and the stated range covers the measured number.
By their numbers in this assay, from the lowest: compound 3; then compounds 4 and 1 (each within the scatter of the next). At a limit, above all of these: compound 2.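

In this assay, a 5.7-fold higher number from compound 3 to compound 4 (0.75 log units; beyond the scatter) gives a direct reading of methoxy against ethyl on this aromatic carbon, ortho to a large group, and the two groups are not interchangeable here despite their equal count of heavy atoms. Methoxy also separates from methyl, an at least 7.6-fold lower number from compound 2 to compound 4 (0.88 log units; beyond the scatter), but that step rests on compound 2, whose value is a limit of the assay and not a number: the limit of > 100000 nM in this assay, at which 1 of the 4 values shown sits. With 2-methoxyphenyl held constant, ethyl in place of hydrogen on the saturated chain carbon bound to the amide-type nitrogen gives a 2.0-fold lower number from compound 1 to compound 4 (0.30 log units; within the scatter), so that change shows no separable effect in this pair.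

From the compounds shown here alone, a longer chain such as propyl, or an amine, at this aromatic carbon remains open. Also open, going by these compounds, is whether the gap between ethyl and methoxy holds when the chain on the amide-type nitrogen changes.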